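The compounds below may be only part of what the source reports. "The series", "measured", "known", "first", "only" and "open" are said of these compounds alone.

In an ADME assay on H9 cells (Homo sapiens) for cytotoxicity, with a stated time of 3 days (on this read-out higher numbers stand for weaker inhibition and lower numbers for stronger inhibition), compound 3 `O=c1cc(-c2ccccc2)oc2c([N+](=O)[O-])c(O)cc(O)c12` gives 12000 nM, the lower of the two numbers in hand. Compound 1 `O=c1cc(-c2ccc(Br)cc2)oc2cc(O)cc(O)c12` gives 21000 nM, which lies within the scatter of the value of compound 3, so the two cannot be separated. For compound 2 `CC(=O)Oc1cc(OC(C)=O)c2c(=O)cc(-c3ccccc3)oc2c1` this assay reports only a limit, > 373000 nM. That entry is the limit of > 373000 nM in this assay, at which 1 of the 3 values shown sits, and no number follows from it. Compound 4 `O=c1cc(-c2ccccc2)oc2c([N+](=O)[O-])c(O)c([N+](=O)[O-])c(O)c12` has not yet been measured in this assay; it differs from compound 3 by nitro in place of hydrogen on an aromatic carbon. Among the measured compounds shown here, no measured pair differing in one place is available, so the size of such a change cannot be read from the data. Compound 4 is expected to stay close to compound 3, with the step of no change at the digits printed from compound 3 to compound 4 (within the scatter) estimated to fall within the scatter in either direction. The estimated value of compound 4 is 12000 nM, in the range 4000 nM to 40000 nM.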

Compound 4, half-maximal inhibitory concentration: 372000 nM
For compound 4 the middle estimate is 31-fold (1.49 log units) below the measured one; measured number above the stated range.
By their numbers in this assay, from the lowest: compounds 3 and 1 (each within the scatter of the next); then compound 4. At a limit, above all of these: compound 2.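

In this assay the aromatic carbon ortho to two hydroxy groups proves sensitive: nitro in place of hydrogen there gives a 31-fold higher number from compound 3 to compound 4 (1.49 log units; beyond the scatter) and so a large step toward weaker inhibition. Among the compounds shown here, the earlier compounds offered no pair differing in one place, so this is the first size that can be read for any change. Nothing measured here accounts for the step. From the compounds shown here alone, whether an amine or a methoxy group on this carbon would shift the number as far stays open, and so does whether nitro would do so without the other nitro group present.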